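The compounds below may be only part of what the source reports. "The series", "measured", "known", "first", "only" and "open" are said of these compounds alone.

Measured compounds:
Compound 1, `COc1ccc(-c2[nH]c3ccccc3c2/C=C(\C#N)S(=O)(=O)c2ccccc2)cc1`: 932 nM
Compound 2, `CCOC(=O)C(=Cc1c(-c2ccccc2)[nH]c2ccccc12)C(=O)OCC`: 2900 nM

Both were tested in a functional assay on NCI-H23 cells (Homo sapiens) for inhibition, read by sulforhodamine B assay, with a stated time of 48 h; on this read-out higher numbers stand for weaker inhibition of growth and lower numbers for stronger inhibition of growth. Compound 1 gives 932 nM, the lowest of the two numbers. Compound 2 gives 2900 nM, a higher number than that of compound 1, and the two values lie beyond the scatter of one another. The two compounds share a core but differ at several places at once, so their values are compared only as two points and no single change is separated out between them.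

Compound 3, `COc1ccc(-c2[nH]c3ccc(OC)cc3c2/C=C(\C#N)S(=O)(=O)c2ccccc2)cc1`, has not yet been measured in this assay. It differs from compound 1 by methoxy in place of hydrogen on an aromatic carbon. Going by the values given here, no pair of measured compounds shows the effect of this change on this assay, so the direction is open. The step from compound 1 to compound 3 is expected to be small, probably no larger than the scatter, and the estimate a 1.2-fold lower number from compound 1 to compound 3 (0.07 log units; within the scatter) reflects that. For compound 3 the expected value in this assay is 800 nM, with a range from 250 nM to 2500 nM.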

Compound 3, concentration for 50% growth inhibition: 946 nM
The estimate for compound 3 lay 1.2-fold (0.07 log units) below the measured number, within the range that was stated.
By their numbers in this assay, from the lowest: compounds 1 and 3 (each within the scatter of the next); then compound 2.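

Methoxy in place of hydrogen on an aromatic carbon of a six-membered aromatic ring of carbon only, part of a fused or bridged system of two rings, gives in this assay a 1.0-fold higher number from compound 1 to compound 3 (0.01 log units; within the scatter) and is the first change in the series that can be read on its own. Within this one pair, the position accepts a methoxy group with no difference beyond the scatter, something compounds 1 and 2 could not show, as they differ at several places at once. No measurement at hand bears on why the added methoxy leaves the two values within the scatter of each other.

On these data alone, whether the same holds for other groups at this position, such as a hydroxy group, an amine, a carboxylic acid or a longer alkoxy chain, remains open, as does the outcome of a methoxy group on another carbon of the same ring. Also open, as far as these compounds go, is whether the same change would give a similar step on a compound carrying the two ethyl esters of compound 2, since a single pair sets no rule for the series.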